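This account rests on a few compounds, and the source may have more. Where it says the series, first, only, none or still open, it means among the compounds named here.

Measured so far in an assay on microsomes from liver for inhibition of sterol O-acyltransferase 1 (Rattus norvegicus); on this read-out lower numbers stand for stronger inhibition and higher numbers for weaker inhibition:
compound 1 `CCCCCCOc1cc(-c2ccccc2)c(-c2ccccc2)nn1` — 72000 nM
compound 2 `CCCCCCCCOc1cc(-c2ccccc2)c(-c2ccccc2)nn1` — 104000 nM

Compound 2 carries the highest number of the two measured, but its distance from compound 1 is within the scatter, so the two cannot be ordered against each other. The step from compound 1 to compound 2, ethyl in place of hydrogen on a saturated chain carbon, six bonds along the chain from an oxygen on an aromatic ring, read as a 1.4-fold higher number from compound 1 to compound 2 (0.16 log units; within the scatter).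

Compound 3 `CCCCCCCCCOc1cc(-c2ccccc2)c(-c2ccccc2)nn1` continues the same chain growth: methyl in place of hydrogen on a saturated chain carbon, eight bonds along the chain from an oxygen on an aromatic ring. Going by the values given here, the only measured step that bears on it is the one from compound 1 to compound 2, which lengthened the same alkoxy chain and changed nothing beyond the scatter. Nothing in the two measured numbers points either way for a further extension, so for this assay no step beyond the scatter is expected from compound 2 to compound 3; the expected step is a 1.2-fold higher number from compound 2 to compound 3 (0.06 log units; within the scatter). Compound 3 is estimated at 120000 nM, with a range from 55000 nM to 260000 nM.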

Compound 3, half-maximal inhibitory concentration: 180000 nM
For compound 3 the middle estimate is 1.5-fold (0.18 log units) below the measured one; measured number inside the range.
By their numbers in this assay, from the lowest: compounds 1, 2 and 3 (each within the scatter of the next, the first and the last beyond it).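

In this assay, methyl in place of hydrogen on a saturated chain carbon, eight bonds along the chain from an oxygen on an aromatic ring, gives a 1.7-fold higher number from compound 2 to compound 3 (0.24 log units; within the scatter), so this single extension, like the one before it, does not separate its two compounds. Going by these compounds alone, the chain growth taken as a whole gives a 2.5-fold higher number from compound 1 to compound 3 (0.40 log units; beyond the scatter): this is the first step beyond the scatter, modest in size, and it places compound 3 on the weaker side of compound 1, while compound 2 cannot be ordered against either of them. Nothing available explains this difference between compound 1 and compound 3.

Open, going by these compounds, is whether a longer chain or a shorter chain would continue this trend on the same core, since three compounds fix only a short stretch of it. Also open, on these data alone, is how an amine or a carboxylic acid in place of the added methyl would read in this assay.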